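Carboxy and bromine on the substituted ring nitrogen

The compounds below may be only part of what the source reports. "The series", "measured", "known", "first", "only" and "open" are said of these compounds alone.

Among the measured compounds shown here, in a functional assay on DU-145 cells (Homo sapiens) for cytotoxicity, read by trypan blue exclusion, with a stated time of 96 h (on this read-out higher numbers stand for weaker inhibition and lower numbers for stronger inhibition), compound 1 `COC(=O)C(C)(C)Nc1cc(NS(=O)(=O)/C=C/c2c(OC)cc(OC)cc2OC)ccc1OC` gives 200 nM and compound 2 `COC(=O)C(Nc1cc(NS(=O)(=O)/C=C/c2c(OC)cc(OC)cc2OC)ccc1OC)c1ccc(Cl)cc1` gives 5000 nM, the higher of the two numbers so far. Compound 3 `COc1cc(OC)c(/C=C/S(=O)(=O)Nc2ccc(OC)c(NC(C(=O)O)c3ccc(Br)cc3)c2)c(OC)c1` has not yet been measured. It carries (4-bromophenyl)(carboxy)methyl in place of (4-chlorophenyl)(methoxycarbonyl)methyl on a nitrogen on an aromatic ring.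

For the measured compounds named here, only one measured step touches this substituent: a 25-fold higher number from compound 1 to compound 2 (1.40 log units; beyond the scatter). That step is large and beyond the scatter, so changes on this nitrogen can clearly move the number in this assay. It does not, however, replace methoxycarbonyl with carboxy or chlorine with bromine, so it offers size only as a loose guide and gives no direction for this change. A moderate move towards a higher number is a tentative expectation, and a result within the scatter would not be surprising. The expected shift is a 1.8-fold higher number from compound 2 to compound 3 (0.26 log units; within the scatter). For compound 3 the estimated value is 9000 nM, with an expected range from 2500 nM to 30000 nM.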

Compound 3, half-maximal inhibitory concentration: 250 nM
Compound 3: the middle estimate sits 36-fold (1.56 log units) above what was measured; measured number outside the range, below it.
By their numbers in this assay, from the lowest: compounds 1 and 3 (each within the scatter of the next); then compound 2.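

In this assay, (4-bromophenyl)(carboxy)methyl in place of (4-chlorophenyl)(methoxycarbonyl)methyl on this nitrogen gives a 20-fold lower number from compound 2 to compound 3 (1.30 log units; beyond the scatter), so a substituent carrying an aromatic ring on this nitrogen does not by itself bring the high number of compound 2. The comparison with the substituent that has no aromatic ring gives a 1.3-fold higher number from compound 1 to compound 3 (0.10 log units; within the scatter), which leaves these two compounds indistinguishable in this assay despite the different groups on the nitrogen. Nothing available gives a reason for either step.

The step between compound 2 and compound 3 changes methoxycarbonyl to carboxy and chlorine to bromine at once, so the compounds shown cannot divide the large shift between those two edits; carboxy paired with chlorine, or methoxycarbonyl paired with bromine, would separate them. From the compounds shown here alone, it also remains open how this nitrogen substituent behaves with a primary amide in place of the carboxy group, or with fluorine in place of the bromine.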